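Adding a methyl to compound 3

The compounds below may be only part of what the source reports. "The series", "measured", "known", "first", "only" and "open" are said of these compounds alone.

- Compound 1 `CSc1cccc(N2C(=O)CN(c3ccccc3)CC2C(=O)NC2CCCC2)c1` gives > 50000 nM (a limit, not a number)
- Compound 2 `CSc1cccc(N2C(=O)CN(c3ccc(C(F)(F)F)cc3)CC2C(=O)NC2CCCC2)c1` gives 10000 nM
- Compound 3 `CSc1cccc(N2C(=O)CN(c3cccc(C(F)(F)F)c3)CC2C(=O)NC2CCCC2)c1` gives 20000 nM

In an ADME assay on HepG2 cells (Homo sapiens) for cytotoxicity (on this read-out higher numbers stand for lower toxicity in this test and lower numbers for higher toxicity in this test), compound 3 lies within the scatter of compound 2 (a 2.0-fold higher number from compound 2 to compound 3 (0.30 log units; within the scatter)). Compound 4 `CSc1cccc(N2C(=O)CN(c3cc(C(F)(F)F)ccc3C)CC2C(=O)NC2CCCC2)c1` differs from compound 3 by one change (methyl in place of hydrogen on an aromatic carbon): methyl in place of hydrogen on an aromatic carbon, ortho to a large group and para to a trifluoromethyl group. Going by the values given here, no measured step adds a methyl. The nearest steps put trifluoromethyl in place of hydrogen on an aromatic carbon, and both start from the limit of compound 1 (an at least 5.0-fold lower number from compound 1 to compound 2 (0.69 log units; beyond the scatter)) (an at least 2.5-fold lower number from compound 1 to compound 3 (0.39 log units; beyond the scatter)). Methyl is the smaller group, so only a small lowering, within the scatter, is expected (a 1.3-fold lower number from compound 3 to compound 4 (0.12 log units; within the scatter)). For compound 4 the estimated value is 15000 nM (expected range 7000 nM to 35000 nM).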

Compound 4, half-maximal cytotoxic concentration: 10000 nM
Beside the measured number, compound 4's estimate is 1.5-fold (0.18 log units) above it; low and high end bracket the measured number.
By their numbers in this assay, from the lowest: compounds 2, 4 and 3 (each within the scatter of the next). At a limit, above all of these: compound 1.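

In this assay, adding the methyl at this place, ortho to a large group and para to a trifluoromethyl group, leaves compound 4 within the scatter of compound 3 (a 2.0-fold lower number from compound 3 to compound 4 (0.30 log units; within the scatter)). Compound 4 also stays within the scatter of compound 2, which carries 4-(trifluoromethyl)phenyl instead (no change at the digits printed from compound 2 to compound 4 (within the scatter)). Only the step from the plain phenyl lies beyond the scatter (an at least 5.0-fold lower number from compound 1 to compound 4 (0.69 log units; beyond the scatter)), and it starts from a limit, not a number: the limit of > 50000 nM in this assay, at which 1 of the 4 values shown sits.

From the compounds shown here alone, whether an amine or a longer chain at this place would stand clear of the scatter remains open. So does what the methyl does on a ring without trifluoromethyl.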